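The compounds below may be only part of what the source reports. "The series", "measured", "known", "first", "only" and "open" are said of these compounds alone.

Working notes on a small salicylanilide set.

Three compounds carry numbers in a functional assay on HL-60 cells (Homo sapiens) for cytotoxicity, read by luminescence and CellTiter-Glo, with a stated time of 3 days; on this read-out higher numbers stand for weaker inhibition and lower numbers for stronger inhibition. Compound 1, `O=C(Nc1ccc(C(F)(F)F)cc1)c1ccc(Cl)cc1O`, gives 630 nM in this assay. Compound 2, `O=C(Nc1cc(C(F)(F)F)cc(C(F)(F)F)c1)c1cc(Cl)c(-c2ccccc2)cc1O`, gives 790 nM in this assay. Compound 3, `N#Cc1cc(Cl)ccc1NC(=O)c1ccc2cccnc2c1O`, gives 790 nM in this assay. On these three numbers compound 1 has the lowest value, but its gaps to compound 2 and to compound 3 both lie within the usual scatter, so the three measured compounds cannot be separated from one another on this read-out.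

The next compound to be measured is compound 4, `O=C(Nc1ccc(C(F)(F)F)cc1)c1ccc(F)cc1O`. It differs from compound 1 in one place: fluoro in place of chloro on an aromatic carbon. The chloro leaves and a fluoro enters, on an aromatic carbon of a six-membered aromatic ring of carbon only, meta to the hydroxy group and para to the large group.

For the measured compounds named here, no measured pair in this set shows such a swap, so there is nothing to scale the step against. The working expectation is a small step toward higher numbers, possibly no larger than the scatter itself, so compound 4 is expected to give 1300 nM in this assay, with a range of 500 nM to 3500 nM. This amounts to an expected step of a 2.1-fold higher number from compound 1 to compound 4 (0.31 log units; beyond the scatter).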

Compound 4, half-maximal inhibitory concentration: 680 nM
Estimate against measurement, compound 4: 1.9-fold (0.28 log units) above, within the range that was stated.
By their numbers in this assay, from the lowest: compounds 1, 4, 2 and 3 (each within the scatter of the next).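

In this assay the change of chloro to fluoro on this aromatic carbon, meta to the hydroxy group and para to the large group, gives a 1.1-fold higher number from compound 1 to compound 4 (0.03 log units; within the scatter), so the read-out does not separate the two halogens at this position. For the compounds shown here, the earlier compounds held no pair differing in one place, and so said nothing about what a change on this carbon alone does; this step is the first scale for it, and it holds for the core of compound 1 only. No measurement in hand bears on why the two halogens read alike, so the result stands as an observation without an explanation.

On these data alone, whether any group on this carbon can move the number beyond the scatter stays open, and an amine, a methoxy group or a carboxylic acid in the place of the halogen would put that to the test. Also open, as far as these compounds go, is whether the same change of chloro to fluoro reads alike on another core, such as the core of compound 2 or compound 3.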